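Replacing a nitrophenyl with a difluorophenyl on the piperazine nitrogen

A few compounds are considered here, and "the series" means these few. Any claim that something is new, unique, unknown or untested is made for them only; others in the source may bear on it.

Compound 1 `Nc1scc(CN2CCN(c3ccc([N+](=O)[O-])cc3)CC2)c1C(=O)c1ccc(Cl)cc1` gives -17% in a functional assay on CHO cells with adenosine receptor A1 (Homo sapiens) as the target, read by cAMP accumulation and immunoassay, with a stated time of 6 min, tested at 10 uM (on this read-out higher numbers stand for a weaker effect at the one concentration tested and lower numbers for a stronger effect), the second highest of three numbers. Compound 3 `Nc1scc(CN2CCN(c3c(F)cccc3F)CC2)c1C(=O)c1cccc(C(F)(F)F)c1` gives 4%, and compound 2 `Nc1scc(CN2CCN(c3cccc(F)c3)CC2)c1C(=O)c1cccc(C(F)(F)F)c1` gives -62%. Among the measured compounds shown here, the one single-point step recorded, a number 66 percentage points higher from compound 2 to compound 3 (beyond the scatter), was large and beyond the scatter. Compound 4 `Nc1scc(CN2CCN(c3ccc(F)cc3F)CC2)c1C(=O)c1ccc(Cl)cc1` differs from compound 1 by 2,4-difluorophenyl in place of 4-nitrophenyl on an amine nitrogen in a ring. That step shares only loosely the move to a difluorophenyl on the ring nitrogen seen from compound 2 to compound 3, and the core aryl differs, so its bearing is weak. A modest rise toward weaker activity is therefore expected, a number 17 percentage points higher from compound 1 to compound 4 (beyond the scatter). Compound 4 is estimated at 0%, within -35% to 35%.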

Compound 4, a percentage reported as activity, at one concentration (the size of the read-out at that concentration, not a potency): -82%
Compound 4: the middle estimate sits 82 percentage points above what was measured; measured number outside the range, below it.
By their numbers in this assay, from the lowest: compound 4; then compound 2; then compound 1; then compound 3.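

At this position, on an amine nitrogen in a ring, 2,4-difluorophenyl in place of 4-nitrophenyl gives a number 65 percentage points lower from compound 1 to compound 4 (beyond the scatter) in this assay, so this single change can shift the read-out strongly toward a stronger effect. The earlier step to a difluorophenyl, a number 66 percentage points higher from compound 2 to compound 3 (beyond the scatter), ran the opposite way, so a difluorophenyl here does not by itself fix the direction of change. No measurement offered here explains the difference. As far as these compounds go, it remains open how 2,4-difluorophenyl behaves with the trifluoromethyl-bearing partner of compound 2 and compound 3, and how a methoxyphenyl or pyridyl group would compare at this nitrogen.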